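Compound 3: methoxycarbonyl to carboxy

A few compounds are considered here, and "the series" means these few. Any claim that something is new, unique, unknown or untested is made for them only; others in the source may bear on it.

Compound 1 `C/C=C1/[C@H](O[C@@H]2O[C@H](COC(C)=O)[C@@H](OC(C)=O)[C@H](OC(C)=O)[C@H]2OC(C)=O)OC=C(C(=O)OC)[C@H]1CC(=O)O`: > 15000 nM
Compound 2 `C/C=C1/[C@H](O[C@@H]2O[C@H](COC(C)=O)[C@@H](OC(C)=O)[C@H](OC(C)=O)[C@H]2OC(C)=O)OC=C(C(=O)OC)[C@H]1CC(=O)SCCc1ccccc1`: > 15000 nM

In a functional assay on SK-BR-3 cells (Homo sapiens) for antiproliferative activity, read by MTT assay, with a stated time of 72 h (a lower number here means a stronger inhibitor, a higher number a weaker inhibitor), compound 1 gives > 15000 nM, which is a limit and not a number. Compound 2 gives > 15000 nM, also a limit. This is all that is known so far: the limit of > 15000 nM in this assay, at which 2 of the 2 values shown sit. Compound 3 `C/C=C1/[C@H](O[C@@H]2O[C@H](COC(C)=O)[C@@H](OC(C)=O)[C@H](OC(C)=O)[C@H]2OC(C)=O)OC=C(C(=O)O)[C@H]1CC(=O)O` differs from compound 1 by one change, hydrogen in place of methyl on an oxygen next to a carbonyl group. Going by the values given here, the only measured step, a step that the two limits leave unreadable from compound 1 to compound 2, is a different change, and its size cannot be read. Nothing measured suggests a gain over compound 1 at > 15000 nM in this assay. The expected step is a step that the limit leaves unreadable from compound 1 to compound 3, with no gain in strength foreseen. For compound 3 the estimate is 20000 nM, with an expected range of 8000 nM to 60000 nM.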

Compound 3, half-maximal inhibitory concentration: > 20000 nM
Compound 3 ended at the assay's limit; the forecaster's own chance of this, stated with the estimate: 80%; the middle value lies on the limit itself.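

Compound 1 and compound 3 both end at limits and not at numbers in this assay, so the step between them cannot be read. The compounds shown leave open whether any change to the shared core gives a measurable value in this assay.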